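Dropping the ester from compound 2 altogether

The source may report more compounds than this note shows. Statements on the series, on what has been measured and on what is new or still open speak of the compounds shown alone.

Compound 2 `CCC(C)OC(=O)c1cccc(NC(=O)c2cccc(-c3cc(C(=O)Nc4ccncc4F)ccc3CN)c2)c1` gives 2.6 nM in an assay on cells for inhibition of Rho-associated protein kinase 2 (Homo sapiens), read by radiometric assay and 33P incorporation, in the presence of a further agent that is not named here (on this read-out higher numbers stand for weaker inhibition and lower numbers for stronger inhibition), the lower of the two numbers seen, and compound 1 `CCCCOC(=O)c1cccc(NC(=O)c2cccc(-c3cc(C(=O)Nc4ccncc4F)ccc3CN)c2)c1` gives 27 nM in this assay. Among the compounds with values here, the only measured step, a 10-fold lower number from compound 1 to compound 2 (1.02 log units; beyond the scatter), shows that this assay is sensitive to what sits on the ester oxygen. Compound 3 `NCc1ccc(C(=O)Nc2ccncc2F)cc1-c1cccc(C(=O)Nc2ccccc2)c1` carries hydrogen in place of sec-butoxycarbonyl on an aromatic carbon, on an aromatic carbon of a six-membered aromatic ring of carbon only. Within the data shown here, no measured step removes the ester entirely, so the change is expected to be large, toward weaker inhibition, about a 12-fold higher number from compound 2 to compound 3 (1.06 log units; beyond the scatter). Compound 3 is therefore estimated at 30 nM, within 6 nM to 150 nM.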

Compound 3, half-maximal inhibitory concentration: < 1 nM
Compound 3: no number, only a limit; the forecaster's own chance of this, stated with the estimate: 3%; middle value at least 30-fold (1.47 log units) away from the limit.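

The value of compound 3 in this assay is a limit of the assay and not a number: the limit of < 1 nM in this assay, at which 1 of the 3 values shown sits. Even so, removing the ester altogether costs no inhibition: hydrogen in place of sec-butoxycarbonyl gives an at least 2.6-fold lower number from compound 2 to compound 3 (0.41 log units; beyond the scatter), and hydrogen in place of butoxycarbonyl gives an at least 27-fold lower number from compound 1 to compound 3 (1.43 log units; beyond the scatter). Within the data shown here, the earlier compounds showed only that the group on the ester oxygen matters, whereas compound 3 shows that strong inhibition does not require an ester on this aromatic carbon.

On these data alone, the true size of both steps stays open, with compound 3 at a limit. Also open, as far as these compounds go, is how an amine or a carboxylic acid on this aromatic carbon would compare.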